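This account rests on a few compounds, and the source may have more. Where it says the series, first, only, none or still open, it means among the compounds named here.

Working notes on the series.

Three compounds have been run in a functional assay on CHO cells for agonist activity at Alpha-1D adrenergic receptor (Homo sapiens), read by FLIPR and calcium flux (a higher number here means that more compound is needed for the effect, a lower number that less compound is needed), so far, with one further compound awaiting measurement. Compound 1 `COc1c(C)ccc2c1CCC2c1ncc[nH]1` reaches only the limit of the assay, giving > 10000 nM in this assay. Compound 2 `c1ccc2c(c1)CCC2c1ncc[nH]1` likewise returns only a limit, > 10000 nM, so its standing within the set is known only as sitting at that boundary rather than as a number. For the measured compounds named here, compound 3 `c1ccc2c(c1)CCCC2c1ncc[nH]1` is the one member with a measured value, 364 nM in this assay. Two of the three values shown therefore sit at the limit (the limit of > 10000 nM in this assay, at which 2 of the 3 values shown sit), and compound 2 is one of them.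

The next compound, compound 4 `CCS(=O)(=O)Nc1cccc2c1CCC2c1ncc[nH]1`, is related to compound 2 by one change: (ethylsulfonyl)amino in place of hydrogen on an aromatic carbon. Going by the values given here, no measured pair in the set shows this change, so its size can only be guessed. Given that compound 2 gives only the limit > 10000 nM in this assay, the step is expected to move toward a measurable value, though possibly not beyond the scatter. The expected step from compound 2 to compound 4 is an at least 4.0-fold lower number from compound 2 to compound 4 (0.60 log units; beyond the scatter). Compound 4 is estimated at 2500 nM in this assay, within a range from 400 nM to 15000 nM.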

Compound 4, half-maximal effective concentration: > 10000 nM
Compound 4: a limit, no number; the forecaster's own chance of this, stated with the estimate: 40%; middle value at least 4.0-fold (0.60 log units) from the limit.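

In this assay compound 4 gives > 10000 nM, a limit and not a number. With compound 2 also at a limit, the step between these two compounds cannot be read: the limit of > 10000 nM in this assay, at which 3 of the 4 values shown sit.

The compounds shown leave open whether (ethylsulfonyl)amino in place of hydrogen on an aromatic carbon changes the value at all.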